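This account rests on a few compounds, and the source may have more. Where it says the series, first, only, none or still open, it means among the compounds named here.

Compound 1, `O=C1O/C(=C\Cn2cc(Cc3ccccc3)nn2)C(OCc2ccccc2)=C1OCc1ccccc1`, gives 71300 nM.
Compound 2, `COC1=C(OC)C(O)(CCn2cc(-c3ccccc3)nn2)NC1=O`, gives 35300 nM.
Compound 3, `CCCc1cn(CCC2(O)C(OCc3ccccc3)=C(OCc3ccccc3)C(=O)N2CCC)nn1`, gives 35000 nM.

These three numbers come from a functional assay on PC-3 cells (Homo sapiens) for antiproliferative activity, read by MTT assay, with a stated time of 24 h; a lower number here means a stronger inhibitor, a higher number a weaker inhibitor. Compound 2 stands second highest of the three: compound 3 sits within the usual scatter of it, while compound 1 lies beyond the scatter, on the weaker side. The new compound 4, `COC1=C(OC)C(O)(CCn2cc(-c3ccc(C(C)(C)C)cc3)nn2)NC1=O`, keeps the whole of compound 2 and differs in one spot only: tert-butyl in place of hydrogen on an aromatic carbon. Going by the values given here, no pair of measured compounds differs by this kind of change, so there is no measured step to lean on. Such a small addition at the far edge of the molecule is expected to shift the number little, if at all, beyond the scatter. The expected step is a 1.2-fold lower number from compound 2 to compound 4 (0.07 log units; within the scatter), and compound 4 is therefore estimated at 30000 nM, somewhere between 10000 nM and 90000 nM.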

Compound 4, half-maximal inhibitory concentration: 30400 nM
Beside the measured number, compound 4's estimate is 1.0-fold (0.01 log units) below it, within the range that was stated.
By their numbers in this assay, from the lowest: compounds 4, 3 and 2 (each within the scatter of the next); then compound 1.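

In this assay, the step is a 1.2-fold lower number from compound 2 to compound 4 (0.06 log units; within the scatter), which lies within the usual scatter. The carbon of the six-membered aromatic ring, para to a large group, therefore carries tert-butyl, a group of 4 heavy atoms, in place of hydrogen with no change that can be told from scatter. Nothing measured here explains this result. Still open, on these data alone, is whether an amine or a carboxylic acid at this same carbon would move the number beyond the scatter.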